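Swapping methoxy for cyano on a trifluoromethyl carbinol

The source may hold more compounds than are shown below. What is called first, only, known or untested is meant among the compounds shown, and "the series" means these compounds.

Values in an ADME assay (liver) for metabolic stability, with Liver microsome (Rattus norvegicus) as the target, using microsomes and NADPH, with a stated time of 30 min (a lower number here means slower removal, a higher number faster removal of the compound), for the three measured compounds:
Compound 1 `CC#C[C@H]1CN(S(=O)(=O)c2ccc(N)nc2)CCN1c1ccc(S(=O)(=O)NC)cn1` gives 42 mL.min-1.g-1
Compound 2 `CC#C[C@H]1CN(S(=O)(=O)c2ccc(N)nc2)CCN1c1ccc(S(N)(=O)=O)cc1` gives 30 mL.min-1.g-1
Compound 3 `CC#C[C@H]1CN(S(=O)(=O)c2ccc(N)nc2)CCN1c1ccc(C(O)(COC)C(F)(F)F)cc1` gives 93 mL.min-1.g-1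

Compound 3 has the highest of the three numbers in this assay and lies beyond the scatter from both compound 1 and compound 2. Compound 4 `CC#C[C@H]1CN(S(=O)(=O)c2ccc(N)nc2)CCN1c1ccc(C(O)(CC#N)C(F)(F)F)cc1` keeps the shared core and changes one group: cyano in place of methoxy on a saturated chain carbon, two bonds along the chain from an aromatic carbon and an oxygen on a saturated carbon (methoxymethyl to cyanomethyl when cut one bond further out). For the measured compounds named here, no measured step makes this exchange. Going by the values given here, the nearest evidence is a 3.1-fold higher number from compound 2 to compound 3 (0.49 log units; beyond the scatter) and it replaces a much larger group on an aromatic carbon, so it shows only that a change there can shift the number modestly. The exchange here is smaller and sits further out, and compound 3 already stands at the top of the measured numbers. A modest fall is therefore expected, estimated as a 1.4-fold lower number from compound 3 to compound 4 (0.16 log units; within the scatter) and uncertain in size. Compound 4 is expected to read 65 mL.min-1.g-1 (estimated range 35 mL.min-1.g-1 to 110 mL.min-1.g-1).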

Compound 4, intrinsic clearance in microsomes: 57 mL.min-1.g-1
Compound 4: middle estimate off by 1.1-fold (0.06 log units), on the high side; the measured number falls inside the stated range.
By their numbers in this assay, from the lowest: compounds 2, 1, 4 and 3 (each within the scatter of the next, the first and the last beyond it).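

In this assay, the exchange of methoxy for cyano on a saturated chain carbon gives a 1.6-fold lower number from compound 3 to compound 4 (0.21 log units; within the scatter), so this first change at this position does not separate the two compounds beyond the scatter. Where a 3.1-fold higher number from compound 2 to compound 3 (0.49 log units; beyond the scatter) was beyond the scatter, a 1.9-fold higher number from compound 2 to compound 4 (0.28 log units; within the scatter) is within it, so the trifluoromethyl carbinol group carrying cyanomethyl, unlike the one carrying methoxymethyl, does not stand clear of the group on the aromatic carbon of compound 2. Nothing available bears on what lies behind these numbers.

The compounds shown leave open whether a different group at this place, such as an amine, a carboxylic acid or a longer chain, would move the number beyond the scatter from compound 3. They also leave open whether cyano in place of methoxy would read the same way on another core.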